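A few compounds are considered here, and "the series" means these few. Any claim that something is new, unique, unknown or untested is made for them only; others in the source may bear on it.

Compound 1, `COc1ccc(N/C=C\C(=O)c2nc(-c3ccc(C(F)(F)F)cc3)n3ccccc23)cc1OC`: in a functional assay on HCT-116 cells (Homo sapiens) for cytotoxicity, read by MTT assay, with a stated time of 48 h (a higher number here means a weaker inhibitor, a lower number a stronger inhibitor), compound 1 gives > 30000 nM, which is a limit of the assay and not a number.
Compound 2, `O=C(/C=C\Nc1ccc2[nH]ccc2c1)c1nc(-c2ccc(C(F)(F)F)cc2)n2ccccc12`: compound 2 gives 27100 nM.
Compound 3, `O=C(/C=C\Nc1ccc(Cl)cc1)c1nc(-c2ccc(C(F)(F)F)cc2)n2ccccc12`: compound 3 gives 11500 nM.

Compound 1 thus stands only at the limit of > 30000 nM in this assay, at which 1 of the 3 values shown sits; no number for it is known, and it is the weakest-looking point among the three. The measured steps all change the group on the amine nitrogen: an at least 1.1-fold lower number from compound 1 to compound 2 (0.04 log units; that floor lies within the scatter), an at least 2.6-fold lower number from compound 1 to compound 3 (0.41 log units; beyond the scatter) and a 2.4-fold lower number from compound 2 to compound 3 (0.37 log units; beyond the scatter).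

Compound 4, `COc1ccc(N/C=C\C(=O)c2nc(-c3ccc(F)cc3)n3ccccc23)cc1OC`, is built differently. It keeps the amine group of compound 1 and instead alters the aryl attached to the shared core: fluoro in place of trifluoromethyl on an aromatic carbon. None of the three measured steps touches that position, so they give no direct guide to the size or direction of this change. With compound 1 already at the limit, the most that can be said is that compound 4 is expected to stay close to it, with no step beyond the scatter expected: a number no higher from compound 1 to compound 4 (the limit leaves the size open). The estimate for compound 4 in this assay is therefore 30000 nM, within a range from 8000 nM to 100000 nM.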

Compound 4, half-maximal inhibitory concentration: > 30000 nM
Compound 4 gave a limit, no number; the forecaster's own chance of this, stated with the estimate: 60%; the middle value lies on the limit itself.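

Among these compounds, compound 1 and compound 4 each give a limit of the assay and not a number, so no step between them can be read: the limit of > 30000 nM in this assay, at which 2 of the 4 values shown sit.

The compounds shown leave open whether 4-fluorophenyl or 4-(trifluoromethyl)phenyl on the shared core gives the lower number in this assay, and by how much.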